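Aryloxybutoxy acyl phenols: acid ring exchange from compound 1

The source may hold more compounds than are shown below. What is called first, only, known or untested is meant among the compounds shown, and "the series" means these compounds.

Measured in an assay on HEK293 cells for positive allosteric modulation of metabotropic glutamate receptor 2 (Rattus norvegicus), read by thallium flux, with a stated time of 2.5 min; on this read-out lower numbers stand for an effect already at smaller amounts and higher numbers for an effect only at larger amounts of compound:

compound 1 `Cc1c(OCCCCOc2ccc(C(=O)O)cc2F)ccc(C(=O)CC2CCCC2)c1O`: 639 nM
compound 2 `Cc1c(OCCCCOc2ccc(C(=O)O)cc2F)ccc(C(=O)CC(C)C)c1O`: 102 nM
compound 3 `Cc1c(OCCCCOc2ccc(C(=O)O)cc2)ccc(C(=O)CC(C)C)c1O`: 122 nM

Compound 1 gives the highest number of the three. The move a 6.3-fold lower number from compound 1 to compound 2 (0.80 log units; beyond the scatter) lies beyond the scatter, as does the gap from compound 1 to compound 3. The change a 1.2-fold higher number from compound 2 to compound 3 (0.08 log units; within the scatter) stays within the scatter.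

Compound 4 `Cc1ccc(C(=O)O)cc1OCCCCOc1ccc(C(=O)CC2CCCC2)c(O)c1C` keeps the cyclopentyl side of compound 1 and alters the acid-bearing ring at the far end of the linker: 5-carboxy-2-methylphenyl in place of 4-carboxy-2-fluorophenyl on an oxygen on a saturated carbon.

Going by the values given here, only one measured step touches this end of the molecule. The exchange of fluoro for hydrogen on that ring, a 1.2-fold higher number from compound 2 to compound 3 (0.08 log units; within the scatter), gave nothing beyond the scatter, so loss of the fluorine by itself is not expected to move the number. Among the compounds with values here, the relocation of the carboxylic acid and the arrival of the methyl have no measured counterpart in this set, and the step of a 6.3-fold lower number from compound 1 to compound 2 (0.80 log units; beyond the scatter) concerns the other end of the molecule and does not bear on it. On these data alone, the expectation is therefore a step within the scatter, a 1.1-fold higher number from compound 1 to compound 4 (0.04 log units; within the scatter), but with a broad range because the acid position is untested. Compound 4 is expected to give 700 nM in this assay, with a range from 200 nM to 2500 nM.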

Compound 4, half-maximal effective concentration: 1290 nM
The estimate for compound 4 lay 1.8-fold (0.27 log units) below the measured number; measured number inside the range.
By their numbers in this assay, from the lowest: compounds 2 and 3 (each within the scatter of the next); then compound 1; then compound 4.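

In this assay, going by these compounds alone, the exchange of 4-carboxy-2-fluorophenyl for 5-carboxy-2-methylphenyl, on an oxygen on a saturated carbon, gives a 2.0-fold higher number from compound 1 to compound 4 (0.31 log units; beyond the scatter) and is the first step at this end of the molecule to lie beyond the scatter, though only modestly. The earlier step on this ring, a 1.2-fold higher number from compound 2 to compound 3 (0.08 log units; within the scatter), stayed within the scatter, so the series now shows that this end can register a change in the number, which loss of fluoro alone did not show. No measurement at hand accounts for the step, and the data do not apportion it between the moved carboxylic acid and the incoming methyl.

The compounds shown leave open how a ring with the carboxylic acid in the same place but hydrogen instead of methyl would read, and whether a 4-carboxy-2-methylphenyl ring would separate the two parts of this exchange. Also open, on these data alone, is whether 5-carboxy-2-methylphenyl gives a step of similar size on the isopropyl side of compound 2, and whether a tetrazole or a primary amide can stand in for the carboxylic acid on either ring.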